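The source may hold more compounds than are shown below. What is called first, only, known or untested is meant among the compounds shown, and "the series" means these compounds.

Compound 1 `COc1cc(OC)c(OC)cc1/C=C/COC(=O)/C=C/c1cccc(Br)c1` was tested in a functional assay on the whole organism (strain Kunming) with Mus musculus as the target, with a stated time of 0.5 h, at a dose of 300 mg/kg by the intraperitoneal route (a higher number here means a weaker effect of the compound at the dose given, a lower number a stronger effect), where compound 1 gives 25%. Compound 2 `COc1cc(OC)c(OC)cc1/C=C/COC(=O)/C=C/c1ccc(OC)c(OC)c1OC`, which carries a different aryl group on the same shared core, was also run in this assay; compound 2 gives 25%, and the two readings are level at the digits shown, a gap within the usual scatter. Compound 1 therefore stands with compound 2, and neither can be called the stronger of the pair. Compound 3 `COc1cc(OC)c(OC)cc1/C=C/COC(=O)/C=C/c1ccc(Cl)cc1` has not yet been measured. It differs from compound 1 in one place: 4-chlorophenyl in place of 3-bromophenyl on a double-bonded chain carbon bound to a double-bonded chain carbon. For the measured compounds named here, no pair of measured compounds differing in one place is available, and the one comparison on hand, compound 1 against compound 2, shows two different aryl groups giving the same number. On that footing the step from compound 1 to compound 3 is expected to be no change at the digits printed from compound 1 to compound 3 (within the scatter), that is, no change beyond the scatter in either direction. Compound 3 is accordingly estimated at 25% in this assay, with a range from 10% to 45%.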

Compound 3, a percentage reported as activity, at one dose (the size of the read-out at that dose, not a potency): 25%
Beside the measured number, compound 3's estimate shows no gap at the digits printed, within the range that was stated.
By their numbers in this assay, from the lowest: compounds 1, 2 and 3 (each within the scatter of the next).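

In this assay, for the compounds shown here, 4-chlorophenyl in place of 3-bromophenyl on a double-bonded chain carbon bound to a double-bonded chain carbon gives no change at the digits printed from compound 1 to compound 3 (within the scatter), the first step here between compounds that differ in one place. The halogen, bromine or chlorine, and the number in the group's name, 3 or 4, differ together in this step, so the result covers the two differences as a pair and cannot be divided between them. Nothing on hand offers an explanation for this result.

The compounds shown leave open whether each of these two differences alone would also stay within the scatter, and whether an aryl ring carrying an amine or a carboxylic acid, or a longer chain in place of the ring, would shift the reading beyond it. They also leave open whether any part of the shared core outside this place bears on the reading, since all three compounds carry that core unchanged.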